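Thiophen-2-yl exchange on the arylidene chain series

A few compounds are considered here, and "the series" means these few. Any claim that something is new, unique, unknown or untested is made for them only; others in the source may bear on it.

Values from a functional assay on KB cells (Homo sapiens) for cytotoxicity; on this read-out higher numbers stand for an effect only at larger amounts of compound and lower numbers for an effect already at smaller amounts:
- compound 1 `COC1=C(C)C(=O)/C(=C(O)/C=C/c2ccc(F)cc2)C(=O)C1(C)C` gives 3.7 ug/mL
- compound 2 `COC1=C(C)C(=O)/C(=C(O)/C=C/c2c(C)cccc2C)C(=O)C1(C)C` gives 7.1 ug/mL

Among the compounds with values here, compound 2, at 7.1 ug/mL in this assay, cannot be separated from compound 1, the only other measured compound. Compound 3 `COC1=C(C)C(=O)/C(=C(O)/C=C/c2cccs2)C(=O)C1(C)C` has not been measured and differs from compound 2 in one place: thiophen-2-yl in place of 2,6-dimethylphenyl on a double-bonded chain carbon bound to a double-bonded chain carbon. The shared core stays the same.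

Within the data shown here, one measured step bears on this place, namely a 1.9-fold higher number from compound 1 to compound 2 (0.28 log units; within the scatter) for 2,6-dimethylphenyl in place of 4-fluorophenyl. Among the measured compounds shown here, no compound with thiophen-2-yl has been measured, and a single step is thin evidence. Still, that step gives no ground to expect a change beyond the scatter in this assay from another exchange at this place. The expected step is a 1.4-fold lower number from compound 2 to compound 3 (0.15 log units; within the scatter) and it is not expected to pass the scatter. For compound 3 the estimated value is 5 ug/mL with an expected range from 2 ug/mL to 12 ug/mL for now.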

Compound 3, concentration for half-maximal effect: 5.5 ug/mL
For compound 3 the middle estimate is 1.1-fold (0.04 log units) below the measured one; measured number inside the range.
By their numbers in this assay, from the lowest: compounds 1, 3 and 2 (each within the scatter of the next).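

Against 2,6-dimethylphenyl, thiophen-2-yl gives a 1.3-fold lower number from compound 2 to compound 3 (0.11 log units; within the scatter) and against 4-fluorophenyl it gives a 1.5-fold higher number from compound 1 to compound 3 (0.17 log units; within the scatter) in this assay at this place on the chain. Within the data shown here, the earlier pair compared only two six-membered aromatic rings of carbon, whereas this exchange brings in a five-membered aromatic ring with sulfur as its hetero atom and a smaller group by heavy-atom count, and still no step among compounds 1, 2 and 3 passes the scatter. Nothing at hand offers an explanation for this flat picture.

Among these compounds, all three compounds carry an aromatic ring at this place, so the series so far shows only that these three rings cannot be told apart in this read-out, not that the place is insensitive to change in general. Going by these compounds, whether a basic amine such as a dimethylaminomethyl group or a carboxylic acid on the ring, or a longer alkyl chain in place of the ring, would yield a step beyond the scatter remains open.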